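The source may report more compounds than this note shows. Statements on the series, on what has been measured and on what is new or still open speak of the compounds shown alone.

Measured so far:
- compound 1 `O=[N+]([O-])c1cn2c(n1)OC[C@@H](OCc1ccc(-c3ccc(C(F)(F)F)cc3)cc1)C2`: 85%
- compound 2 `O=[N+]([O-])c1cn2c(n1)OC[C@@H](OCc1ccc(-c3ccc(OC(F)(F)F)cc3)cc1)C2`: 96%
- compound 3 `O=[N+]([O-])c1cn2c(n1)OC[C@@H](OCc1ccc(-c3ccc(Cl)c(OC(F)(F)F)c3)cc1)C2`: 92%

All three values come from an ADME assay on microsomes from liver (Mus musculus, strain CD1) for metabolic stability, read by LC-MS, with a stated time of 1 h; a higher number here means that more of the compound is left, a lower number that less of the compound is left. From compound 2 to compound 1 the change is trifluoromethyl in place of trifluoromethoxy on an aromatic carbon, and the step is a number 11 percentage points lower from compound 2 to compound 1 (beyond the scatter). Compound 3 lies within the scatter of both compound 2 and compound 1. How the core of compound 3 differs from the core of compound 2 is not broken down here.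

Compound 4 `O=[N+]([O-])c1cn2c(n1)OC[C@@H](OCc1ccc(-c3ccc(Cl)c(C(F)(F)F)c3)cc1)C2` is not yet measured. From compound 3 to compound 4 the change is trifluoromethyl in place of trifluoromethoxy on an aromatic carbon. It is the same kind of change as from compound 2 to compound 1, but not the same: there the entering group sits para to a large group, here it sits ortho to a chloro group and meta to a large group. The step is expected to be a number 10 percentage points lower from compound 3 to compound 4 (within the scatter). This rests on a number 11 percentage points lower from compound 2 to compound 1 (beyond the scatter) and on compound 3 at 92%. Compound 4 is estimated at 82%, from 68% to 94%.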

Compound 4, percent of the compound remaining: 96%
The estimate for compound 4 lay 14 percentage points below the measured number; the whole stated range lies below it.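

Trifluoromethyl in place of trifluoromethoxy does not carry from one core to the other as a fixed step in this assay: the same change on two cores in this assay, a number 11 percentage points lower (beyond the scatter) from compound 2 to compound 1 and a number 4 percentage points higher (within the scatter) from compound 3 to compound 4, 15 percentage points apart, beyond the scatter of two such steps. On the core with the chloro group, the change reads a number 4 percentage points higher from compound 3 to compound 4 (within the scatter), so no lowering of the kind seen on the other core can be read there. With a single pair on each core, this does not show what separates the two steps, since the cores differ both in the chloro group and in the place of the changing group.

Open, from the compounds shown here alone, is how the step reads with a nitrile or a methoxy group in place of the chloro group. Also open, going by these compounds, is how an amine or a carboxylic acid would read in place of trifluoromethyl.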